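A few compounds are considered here, and "the series" means these few. Any claim that something is new, unique, unknown or untested is made for them only; others in the source may bear on it.

Measured in a physicochemical assay for solubility, read by spectrophotometry, in phosphate buffer, with a stated time of 18 h, at pH 7.4; on this read-out higher numbers stand for higher solubility and lower numbers for lower solubility:
- compound 1 `CCc1ccc(-c2nc3c(c(C)nn3-c3ccccc3)c(-c3ccccc3C(=O)OC)c2C#N)cc1`: 17000 nM
- compound 2 `Cc1ccc(-c2nc3c(c(C)nn3-c3ccccc3)c(-c3ccccc3O)c2C#N)cc1`: 26000 nM
- compound 3 `Cc1ccccc1-c1nc2c(c(C)nn2-c2ccccc2)c(-c2ccccc2O)c1C#N`: 21000 nM

In this assay, compound 3 at 21000 nM lies within the scatter of both other compounds, so the three values do not separate it from either of them.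

Compound 4 `Cc1nn(-c2ccccc2)c2nc(-c3ccc4ccccc4c3)c(C#N)c(-c3ccccc3O)c12` carries naphthalen-2-yl in place of the 2-methylphenyl of compound 3, on the aromatic carbon ortho to the cyano group: naphthalen-2-yl in place of 2-methylphenyl on an aromatic carbon.

Among the compounds with values here, one measured step bears on this change, a 1.2-fold lower number from compound 2 to compound 3 (0.09 log units; within the scatter). It also exchanges the group on that aromatic carbon, but it only moves a methyl group and stays within the scatter. Within the data shown here, no measured compound carries naphthalen-2-yl, so the data give no firm direction, and the range must stay wide. A step no larger than the usual scatter is expected, with a slight lean towards lower numbers. The expected step is a 1.5-fold lower number from compound 3 to compound 4 (0.18 log units; within the scatter). For compound 4 the estimated value is 14000 nM, with an expected range from 5000 nM to 28000 nM.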

Compound 4, solubility: 1800 nM
Estimate against measurement, compound 4: 7.8-fold (0.89 log units) above; measured number below the stated range.
By their numbers in this assay, from the lowest: compound 4; then compounds 1, 3 and 2 (each within the scatter of the next).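

In this assay, the aromatic carbon ortho to a cyano group turns out to be a place where the read-out can move well beyond the scatter: naphthalen-2-yl gives a 12-fold lower number from compound 3 to compound 4 (1.07 log units; beyond the scatter), and the same group set against 4-methylphenyl gives a 14-fold lower number from compound 2 to compound 4 (1.16 log units; beyond the scatter). The exchange between the two methylphenyl groups, a 1.2-fold lower number from compound 2 to compound 3 (0.09 log units; within the scatter), had given no sign of this, so moving a methyl group at this place said nothing about what a group with 2 six-membered aromatic rings would do. Nothing measured here accounts for the size of these steps.

The compounds shown leave open whether a single ring carrying an amine or a carboxylic acid at this place would stay with compound 3 or fall with compound 4. They also leave open whether naphthalen-2-yl would give a step of this size where the 2-hydroxyphenyl group is replaced, as it is in compound 1.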